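From 4-nitrophenyl ethenyl to 3-hydroxyphenyl ethynyl

The compounds below may be only part of what the source reports. "The series", "measured", "known", "first", "only" and "open" are said of these compounds alone.

Within the data shown here, in a functional assay on NIH3T3 cells (Mus musculus) (on this read-out lower numbers stand for an effect already at smaller amounts and higher numbers for an effect only at larger amounts of compound), compound 2 (`Cn1cncc1C(OCc1ccc(C#N)cc1/C=C/c1ccc([N+](=O)[O-])cc1)c1ccc(C#N)cc1`) gives 2.24 nM as the lower of the two numbers so far, and compound 1 (`Cn1cncc1C(OCc1ccc(C#N)cc1/C=C/c1ccccn1)c1ccc(C#N)cc1`) gives 23.1 nM as the higher. The change to compound 3 (`Cn1cncc1C(OCc1ccc(C#N)cc1C#Cc1cccc(O)c1)c1ccc(C#N)cc1`) is 2-(3-hydroxyphenyl)ethynyl in place of 2-(4-nitrophenyl)ethenyl on an aromatic carbon and it sits on an aromatic carbon, ortho to a large group and meta to a cyano group. Among the measured compounds shown here, the one measured step that bears on it is a 10-fold lower number from compound 1 to compound 2 (1.01 log units; beyond the scatter) and it is large, with 4-nitrophenyl in place of pyridin-2-yl at the same place. For the measured compounds named here, no measured compound carries the triple bond or the 3-hydroxyphenyl group, so that step is only a weak guide. The expected change is a 2.7-fold higher number from compound 2 to compound 3 (0.43 log units; beyond the scatter) in this assay as a moderate step toward a higher number. In this assay compound 3 is estimated at 6 nM (range 1.5 nM to 25 nM).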

Compound 3, half-maximal effective concentration: > 0.1 nM
Compound 3: no number, only a limit; the forecaster's own chance of this, stated with the estimate: 3%; the middle value does not contradict the limit.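

In this assay compound 3 gives only the limit > 0.1 nM and no number, and the steps to it from compound 1 and compound 2 cannot be read. On these data alone, whether 2-(3-hydroxyphenyl)ethynyl gives a lower or higher number than either 2-(4-nitrophenyl)ethenyl or 2-(pyridin-2-yl)ethenyl stays open.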